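Swapping ethoxycarbonyl for propyl on the shared core

The source may report more compounds than this note shows. Statements on the series, on what has been measured and on what is new or still open speak of the compounds shown alone.

In a functional assay (B cells) with Mus musculus as the target (on this read-out lower numbers stand for an effect already at smaller amounts and higher numbers for an effect only at larger amounts of compound), compound 1 (`COc1ccc(Cn2c(=O)n(C3OC(CO)[C@@H](O)[C@H]3O)c3nc(N)nc(O)c32)cc1`) gives 135 uM and compound 2 (`CCOC(=O)Cn1c(=O)n(C2OC(CO)[C@@H](O)[C@H]2O)c2nc(N)nc(O)c21`) gives 48 uM as the lower of the two numbers. Compound 3 (`CCCCn1c(=O)n(C2OC(CO)[C@@H](O)[C@H]2O)c2nc(N)nc(O)c21`) is still unmeasured. It keeps the shared core of compound 2 and swaps one group: propyl in place of ethoxycarbonyl on a saturated chain carbon bound to an aromatic nitrogen. Cut one bond further out, that reads (ethoxycarbonyl)methyl to butyl. Among the measured compounds shown here, one measured step bears on this place, and a 2.8-fold lower number from compound 1 to compound 2 (0.45 log units; beyond the scatter) is only modest. For the measured compounds named here, it shows that a change here can shift the number, but no measured compound carries a butyl chain, so the data give no direction. In this assay no step beyond the scatter is therefore expected. The estimated step is a 1.0-fold higher number from compound 2 to compound 3 (0.02 log units; within the scatter) and nothing larger. For compound 3 the estimate is 50 uM with an expected range of 18 uM to 140 uM in this read-out.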

Compound 3, concentration for half-maximal effect: 11 uM
Compound 3: the middle estimate sits 4.5-fold (0.66 log units) above what was measured; measured number outside the range, below it.
By their numbers in this assay, from the lowest: compound 3; then compound 2; then compound 1.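

In this assay this position on a saturated chain carbon bound to an aromatic nitrogen now shows more than a shift of unknown direction: propyl in place of ethoxycarbonyl gives a 4.4-fold lower number from compound 2 to compound 3 (0.64 log units; beyond the scatter) and propyl in place of 4-methoxyphenyl gives a 12-fold lower number from compound 1 to compound 3 (1.09 log units; beyond the scatter) as the largest step among these compounds. The butyl chain of compound 3 has no ring and no hydrogen-bond acceptors, so neither feature of the group at this position is needed for the lowest number of the three. The data shown offer no explanation for these steps.

Going by these compounds, it remains open whether a longer chain, such as hexyl, would lower the number further or a shorter one, such as ethyl, would raise it. On these data alone, the effect of placing an amine or a carboxylic acid at the end of the chain is also open.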